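Methylsulfanyl for Fluoro: What to Expect of Compound 4

The source may report more compounds than this note shows. Statements on the series, on what has been measured and on what is new or still open speak of the compounds shown alone.

Three compounds share one core and differ only in the group on an aromatic nitrogen. Compound 1 `Cc1ccccc1-c1nn(Cc2ccc(F)cc2)cc1CNCCN1CCN(C)CC1` carries 4-fluorobenzyl there, compound 2 `Cc1ccccc1-c1nn(-c2ccccc2Cl)cc1CNCCN1CCN(C)CC1` carries 2-chlorophenyl, and compound 3 `Cc1ccccc1-c1nn(-c2ccc(F)cc2)cc1CNCCN1CCN(C)CC1` carries 4-fluorophenyl. In an ADME assay on Huh-7 cells (Homo sapiens) for cytotoxicity (a lower number here means that less compound is tolerated, a higher number that more compound is tolerated), compound 1 gives only a limit, > 20000 nM. In this assay compound 2 likewise gives a limit, > 20000 nM. In this assay compound 3 also reaches only a limit, > 20000 nM. Accordingly the steps a step that the two limits leave unreadable from compound 1 to compound 2, a step that the two limits leave unreadable from compound 1 to compound 3 and a step that the two limits leave unreadable from compound 2 to compound 3 cannot be sized; all three values sit together at the limit of > 20000 nM in this assay, at which 3 of the 3 values shown sit.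

Compound 4 `CSc1ccc(-n2cc(CNCCN3CCN(C)CC3)c(-c3ccccc3C)n2)cc1` differs from compound 3 by methylsulfanyl in place of fluoro on an aromatic carbon. Among the compounds with values here, no measured step bears directly on this change: the three measured steps concern the group on the aromatic nitrogen, and each is unreadable. Within the data shown here, the only guide is that every value so far sits at the limit of > 20000 nM in this assay, at which 3 of the 3 values shown sit. Compound 3 therefore stands at that limit with no number of its own. Compound 4 is expected to remain at or near the limit in this assay, and the step that the limit leaves unreadable from compound 3 to compound 4 is expected to be small or again not readable. The estimate for compound 4 in this assay is 25000 nM, within 10000 nM to 60000 nM.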

Compound 4, half-maximal cytotoxic concentration: 17000 nM
Beside the measured number, compound 4's estimate is 1.5-fold (0.17 log units) above it; measured number inside the range.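

In this assay compound 4 is the only one of the four shown to give a number rather than a limit, so methylsulfanyl in place of fluoro, para to a large group, yields a step with a floor: an at least 1.1-fold lower number from compound 3 to compound 4 (0.07 log units; that floor lies within the scatter). The changes on the aromatic nitrogen now have the same kind of floor, in an at least 1.1-fold lower number from compound 2 to compound 4 (0.07 log units; that floor lies within the scatter) and in an at least 1.1-fold lower number from compound 1 to compound 4 (0.07 log units; that floor lies within the scatter), and none of these three floors is shown to lie beyond the scatter. The steps among compound 1, compound 2 and compound 3 still cannot be read, and most of the set remains at one limit: the limit of > 20000 nM in this assay, at which 3 of the 4 values shown sit.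

From the compounds shown here alone, the true size of the step at this position remains open, as compound 3 has no number of its own. Also open, going by these compounds, is how methoxy, an amine or a longer thioether chain at the same place would read in this assay.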